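A Leucine-Type Side Chain Replacing Glutamine in Compound 1

A few compounds are considered here, and "the series" means these few. Any claim that something is new, unique, unknown or untested is made for them only; others in the source may bear on it.

Among the compounds with values here, compound 1 `NC(=O)CC[C@H](NC(=O)CN(c1ncnc2c1ncn2C1CCCCO1)C1CC1)C(=O)OCc1ccccc1` is one of three compounds measured in a functional assay on the whole organism (Tail, strain ICR) with Mus musculus as the target, in the tail flick test, with a stated time of 150 min, at a dose of 25 umol/kg by the oral route; a higher number here means a stronger effect of the compound at the dose given, a lower number a weaker effect. In this assay compound 1 gives 10.7%, the second highest of the three numbers. Compound 2 `O=C(OCc1ccccc1)[C@@H]1CCCN1C(=O)CN(c1ncnc2c1ncn2C1CCCCO1)C1CC1` gives 7.85%, a value within the scatter of compound 1. Compound 3 `NC(=O)CC[C@H](NC(=O)CN(c1nc(Cl)nc2[nH]cnc12)C1CC1)C(=O)OCc1ccccc1` gives 31.1%, a gap beyond the scatter from compound 1. Compound 4 `CC(C)C[C@H](NC(=O)CN(c1ncnc2c1ncn2C1CCCCO1)C1CC1)C(=O)OCc1ccccc1` has not yet been measured. It differs from compound 1 in one place: isopropyl in place of carbamoylmethyl on a saturated chain carbon, two bonds along the chain from an amide-type nitrogen and a carbonyl carbon. Within the data shown here, no measured pair shows this change, so the data give no direct guide to its effect. Compound 4 is estimated at 12%, with a range from 3% to 28%. The step of a number 1.3 percentage points higher from compound 1 to compound 4 (within the scatter) is expected to be none beyond the scatter.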

Compound 4, a percentage reported as activity, at one dose (the size of the read-out at that dose, not a potency): 6.47%
Compound 4: the middle estimate sits 5.5 percentage points above what was measured; low and high end bracket the measured number.
By their numbers in this assay, from the lowest: compounds 4, 2 and 1 (each within the scatter of the next); then compound 3.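

In this assay, within the data shown here, the first measured exchange at this position, isopropyl in place of carbamoylmethyl, gives a number 4.2 percentage points lower from compound 1 to compound 4 (within the scatter). Compound 1 and compound 4 therefore stand within the scatter of each other, even though the hydrogen-bond donor and acceptor of carbamoylmethyl are absent from isopropyl. Nothing available explains this result. Going by these compounds, whether an amine, a carboxylic acid or a longer chain on this carbon would give a step beyond the scatter remains open. On these data alone, it is also open whether isopropyl would give a similar step on a core other than that of compound 1.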